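The compounds below may be only part of what the source reports. "The series", "measured", "known", "first", "only" and "open" are said of these compounds alone.

Compound 1 `Cc1c(C(=O)Nc2ccc(Oc3ncnc4[nH]cc(-c5ccccc5)c34)c(F)c2)c(=O)c2ccccc2n1C` is the parent of this small set. In an assay on isolated protein for inhibition of tyrosine-protein kinase receptor UFO (Homo sapiens), read by FRET and Z'-LYTE, with a stated time of 1.5 h (on this read-out lower numbers stand for stronger inhibition and higher numbers for weaker inhibition), compound 1 gives > 10000 nM, which is a limit of the assay rather than a number. Compound 2 `Cc1c(C(=O)Nc2ccc(Oc3ncnc4[nH]cc(-c5ccccc5)c34)c(F)c2)c(=O)c2c(Cl)cccc2n1C` carries a chloro in place of hydrogen on an aromatic carbon, and in this assay compound 2 gives > 10000 nM, again a limit. Compound 3 `Cc1c(C(=O)Nc2ccc(Oc3ncnc4[nH]cc(-c5ccccc5)c34)c(F)c2)c(=O)c2ccc(Cl)cc2n1C` places its chloro on a different aromatic carbon, and in this assay compound 3 gives > 10000 nM, also a limit. Accordingly a step that the two limits leave unreadable from compound 1 to compound 2 and a step that the two limits leave unreadable from compound 1 to compound 3 cannot be sized, since (the limit of > 10000 nM in this assay, at which 3 of the 3 values shown sit). Compound 4 `Cc1c(C(=O)Nc2ccc(Oc3ncnc4[nH]cc(-c5ccccc5)c34)c(F)c2)c(=O)c2cc(C3CC3)ccc2n1C` differs from compound 1 by cyclopropyl in place of hydrogen on an aromatic carbon. With no readable step to lean on, no direction beyond the scatter is expected for the step that the limit leaves unreadable from compound 1 to compound 4. Compound 4 is therefore expected near 15000 nM, between 3000 nM and 60000 nM, most likely reported again only as a limit.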

Compound 4, half-maximal inhibitory concentration: 230 nM
Compound 4: the middle estimate sits 65-fold (1.81 log units) above what was measured, and the stated range ends above it.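

In this assay, among these compounds, cyclopropyl in place of hydrogen on an aromatic carbon gives an at least 43-fold lower number from compound 1 to compound 4 (1.63 log units; beyond the scatter) and is the first readable step in this set. It shows that a change on this six-membered aromatic ring of the core can bring a compound to a measurable number. The steps to compound 2 and compound 3 cannot be read: the limit of > 10000 nM in this assay, at which 3 of the 4 values shown sit.

The compounds shown leave open whether this result is particular to cyclopropyl. From the compounds shown here alone, a methyl, a methoxy or an amine on the same carbon remains untested here.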